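Amide-to-benzyl switch on the piperazine series

The compounds below may be only part of what the source reports. "The series", "measured", "known", "first", "only" and "open" are said of these compounds alone.

Compound 3 `COc1ccc(-c2cnc3nc(N)nc(N4CCN(C(=O)Nc5cccc(C)c5)CC4)c3n2)cc1OC` gives 7 nM in a functional assay on cells (T-cell, Homo sapiens) for inhibition; a higher number here means a weaker inhibitor, a lower number a stronger inhibitor. Among the three measured compounds it holds the second highest number: compound 1 `COc1ccc(-c2cnc3nc(N)nc(N4CCN(C(=O)Nc5ccc(C)cc5)CC4)c3n2)cc1OC` gives 0.8 nM, and the step of an 8.8-fold higher number from compound 1 to compound 3 (0.94 log units; beyond the scatter) is modest; compound 2 `COc1ccc(-c2cnc3nc(N)nc(N4CCN(C(=O)c5ccccc5)CC4)c3n2)cc1OC` gives 400 nM, and the step of a 57-fold lower number from compound 2 to compound 3 (1.76 log units; beyond the scatter) is large.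

Compound 4 `COc1ccc(-c2cnc3nc(N)nc(N4CCN(Cc5c(Cl)cccc5Cl)CC4)c3n2)cc1OC` differs from compound 3 as follows: 2,6-dichlorobenzyl in place of (3-methylphenyl)carbamoyl on an amine nitrogen in a ring. Among the compounds with values here, no measured step removes the carbonyl itself, so the change is only partly covered. The nearest guide is a 500-fold higher number from compound 1 to compound 2 (2.70 log units; beyond the scatter), where the group on the carbonyl carbon lost its nitrogen and a large weakening followed; the step of a 57-fold lower number from compound 2 to compound 3 (1.76 log units; beyond the scatter) shows the same feature in the other direction. Compound 4 loses the carbonyl, the donor and the acceptor at once, so a large rise in this assay is expected, of about a 110-fold higher number from compound 3 to compound 4 (2.06 log units; beyond the scatter). Compound 4 is therefore estimated at 800 nM, within 80 nM to 8000 nM.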

Compound 4, half-maximal inhibitory concentration: 7600 nM
The estimate for compound 4 lay 9.5-fold (0.98 log units) below the measured number; low and high end bracket the measured number.
By their numbers in this assay, from the lowest: compound 1; then compound 3; then compound 2; then compound 4.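

In this assay, within the data shown here, 2,6-dichlorobenzyl on the ring nitrogen gives the largest rise so far, with a 1100-fold higher number from compound 3 to compound 4 (3.04 log units; beyond the scatter) against the (3-methylphenyl)carbamoyl group and a 9500-fold higher number from compound 1 to compound 4 (3.98 log units; beyond the scatter) against the (4-methylphenyl)carbamoyl group. The rise continues past the benzoyl level, with a 19-fold higher number from compound 2 to compound 4 (1.28 log units; beyond the scatter), so compound 4 is the weakest of the four and the loss at this position does not stop at the benzoyl compound. No measurement bears on the cause of these steps.

This change removes the carbonyl and brings in the two chlorines in a single step, so the share of each stays unresolved. Plain benzyl, without chlorine, would separate the two, and a sulfonyl link or a 2-phenylethyl chain on the same nitrogen remains an open question.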